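Halogen swaps on the anilide ring: compound 3 to compound 4

This account rests on a few compounds, and the source may have more. Where it says the series, first, only, none or still open, it means among the compounds named here.

Measured in a functional assay on MGC-803 cells (Homo sapiens) for inhibition, read by MTT assay, with a stated time of 72 h; a higher number here means a weaker inhibitor, a lower number a stronger inhibitor:
compound 1 `Cc1ccc(NC(=O)C2CCN(C/C=C/c3ccccc3)CC2)cc1`: 24100 nM
compound 2 `O=C(Nc1cccc(F)c1)C1CCN(C/C=C/c2ccccc2)CC1`: 23300 nM
compound 3 `O=C(Nc1cccc(Cl)c1)C1CCN(C/C=C/c2ccccc2)CC1`: 11300 nM

Compound 3 holds the lowest of the three numbers in this assay, at 11300 nM. The next structure is compound 4 `O=C(Nc1ccc(F)c(Br)c1)C1CCN(C/C=C/c2ccccc2)CC1`, with this difference: 3-bromo-4-fluorophenyl in place of 3-chlorophenyl on an amide-type nitrogen. In words, 3-bromo-4-fluorophenyl stands in place of 3-chlorophenyl on an amide-type nitrogen.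

The closest measured precedent is a 2.1-fold lower number from compound 2 to compound 3 (0.31 log units; beyond the scatter), where chloro replaces fluoro on an aromatic carbon. The step of a 2.1-fold lower number from compound 1 to compound 3 (0.33 log units; beyond the scatter) is of similar size, while a 1.0-fold lower number from compound 1 to compound 2 (0.01 log units; within the scatter) shows that an aryl change can also leave the number unmoved. For the measured compounds named here, no measured compound carries bromo, so the evidence is thin.

A slight lean toward a lower number is expected, and the estimated step is a 1.4-fold lower number from compound 3 to compound 4 (0.15 log units; within the scatter). The estimated value for compound 4 is 8000 nM. The expected range for compound 4 runs from 3500 nM to 18000 nM.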

Compound 4, half-maximal inhibitory concentration: 9270 nM
Estimate against measurement, compound 4: 1.2-fold (0.06 log units) below; the measured number falls inside the stated range.
By their numbers in this assay, from the lowest: compounds 4 and 3 (each within the scatter of the next); then compounds 2 and 1 (each within the scatter of the next).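

In this assay, the step to 3-bromo-4-fluorophenyl on the amide-type nitrogen gives a 1.2-fold lower number from compound 3 to compound 4 (0.09 log units; within the scatter), so this position takes a ring with two halogens and the number stays level with that of the single-chloro ring. The same ring stands clear of the other two aryl groups, with a 2.5-fold lower number from compound 2 to compound 4 (0.40 log units; beyond the scatter) and a 2.6-fold lower number from compound 1 to compound 4 (0.41 log units; beyond the scatter), which places 3-chlorophenyl and 3-bromo-4-fluorophenyl together, apart from 3-fluorophenyl and 4-methylphenyl. No supporting data bear on why the number behaves this way.

The compounds shown do not separate the contribution of bromo from that of the added fluoro within this single change. Also open, as far as these compounds go, is whether an amine or a carboxylic acid on this aryl ring would move the number beyond the scatter from compound 4.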